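Series notes: propylsulfonyl in place of the sulfonamide

A few compounds are considered here, and "the series" means these few. Any claim that something is new, unique, unknown or untested is made for them only; others in the source may bear on it.

Measured in an assay on CHO cells for displacement of a labelled ligand from prostaglandin D2 receptor 2 (Homo sapiens), read by scintillation counting; on this read-out lower numbers stand for stronger inhibition and higher numbers for weaker inhibition:
compound 1 `CCCS(=O)(=O)c1cccc(C#Cc2cc(F)ccc2OCC(=O)O)c1` gives 65 nM
compound 2 `CS(=O)(=O)c1cccc(C#Cc2cc(Cl)ccc2OCC(=O)O)c1` gives 15 nM
compound 3 `CN(c1cccc(C#Cc2cc(Cl)ccc2OCC(=O)O)c1)S(C)(=O)=O` gives 122 nM

Compound 3 carries the highest of the three numbers in this assay; its gap to compound 1 lies within the scatter, while its gap to compound 2 lies beyond it. Compound 4 `CCCS(=O)(=O)c1cccc(C#Cc2cc(Cl)ccc2OCC(=O)O)c1` is not yet measured. It differs from compound 3 in one place: propylsulfonyl in place of methyl(methylsulfonyl)amino on an aromatic carbon.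

For the measured compounds named here, the single measured step that bears on this change is the one that replaces a sulfonyl by the sulfonamide, an 8.1-fold higher number from compound 2 to compound 3 (0.91 log units; beyond the scatter). Compound 4 runs that change in reverse, back to a sulfonyl, though with propyl rather than methyl on the sulfur. Going by the values given here, compound 1 and compound 2 differ in two places, so no single step joins them; their values show that the propylsulfonyl compound has a higher number than the methylsulfonyl compound, which tempers the expectation somewhat. A step down in this assay beyond the scatter is therefore expected, a 4.9-fold lower number from compound 3 to compound 4 (0.69 log units; beyond the scatter). Compound 4 is expected to give about 25 nM in this assay, within a range from 10 nM to 70 nM.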

Compound 4, inhibition constant: 9 nM
The estimate for compound 4 lay 2.8-fold (0.44 log units) above the measured number, and the stated range ends above it.
By their numbers in this assay, from the lowest: compounds 4 and 2 (each within the scatter of the next); then compounds 1 and 3 (each within the scatter of the next).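

With the shared core held fixed, this assay gives a 14-fold lower number from compound 3 to compound 4 (1.13 log units; beyond the scatter) on replacing methyl(methylsulfonyl)amino with propylsulfonyl on this aromatic carbon; the two groups have the same counts of heavy atoms and hydrogen-bond acceptors, so these counts do not separate them. For the compounds shown here, the propyl chain is now compared directly with methyl on the sulfonyl, and a 1.7-fold lower number from compound 2 to compound 4 (0.22 log units; within the scatter) shows no difference that can be read beyond the scatter, while the halogen change, chloro in place of fluoro, is isolated for the first time as a 7.2-fold lower number from compound 1 to compound 4 (0.86 log units; beyond the scatter) with propylsulfonyl in place. No supporting data are available to explain any of these steps.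

The compounds shown leave open how far the sulfonyl chain can be extended, which butylsulfonyl or isopropylsulfonyl at this position would test. They also leave open whether a sulfonyl is needed here at all, which a ketone or an amide in the same place would address, and whether the halogen step seen with propylsulfonyl also holds with methylsulfonyl.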